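From Furan-2-yl to Pyridin-2-yl on the Amide Chain

The compounds below may be only part of what the source reports. "The series", "measured", "known", "first", "only" and "open" are said of these compounds alone.

Of the compounds shown here, two with a shared core have been measured. Compound 2 `O=C(Cn1c(=O)oc2cc([N+](=O)[O-])ccc21)NCc1ccco1` carries a (furan-2-yl)methyl group on an amide-type nitrogen, while compound 1 `O=C(Cn1c(=O)oc2cc([N+](=O)[O-])ccc21)Nc1ccccc1` carries a phenyl group there. In an ADME assay on RAW264.7 cells (Mus musculus) for cytotoxicity, read by MTT assay, with a stated time of 72 h, tested at 50 uM (on this read-out higher numbers stand for a stronger effect at the one concentration tested and lower numbers for a weaker effect), compound 2 gives 26.8%, and compound 1 gives 18%. The step of a number 8.8 percentage points higher from compound 1 to compound 2 (within the scatter) lies within the scatter, so compound 2 stands apart from compound 1 by no more than measurement noise, even though its number is the one nearer the top of the two.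

Compound 3 `O=C(Cn1c(=O)oc2cc([N+](=O)[O-])ccc21)NCc1ccccn1` has not yet been measured. It differs from compound 2 by pyridin-2-yl in place of furan-2-yl on a saturated chain carbon bound to an amide-type nitrogen. For the measured compounds named here, the only measured step, a number 8.8 percentage points higher from compound 1 to compound 2 (within the scatter), concerns a different exchange and was itself within the scatter, so the data give no reason to expect a large movement here: one aromatic ring with one hetero atom is swapped for another of the same kind. Compound 3 is therefore expected to stay near compound 2, with an estimated step of a number 1.8 percentage points lower from compound 2 to compound 3 (within the scatter) in this assay. The estimate for compound 3 is 25%, with a range from 10% to 40%.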

Compound 3, a percentage reported as inhibition, at one concentration (the size of the read-out at that concentration, not a potency): 21.8%
Compound 3: middle estimate off by 3.2 percentage points, on the high side; low and high end bracket the measured number.
By their numbers in this assay, from the lowest: compounds 1, 3 and 2 (each within the scatter of the next).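

In this assay, putting pyridin-2-yl in place of furan-2-yl on a saturated chain carbon bound to an amide-type nitrogen gives a number 5 percentage points lower from compound 2 to compound 3 (within the scatter) and so shows that a five-membered aromatic ring with an oxygen can give way to a six-membered aromatic ring with a nitrogen without the read-out leaving the usual scatter. Compared with the phenyl group on the amide-type nitrogen, (pyridin-2-yl)methyl gives a number 3.8 percentage points higher from compound 1 to compound 3 (within the scatter) and thus adds a second exchange at this nitrogen that stays within the scatter, so compound 1, compound 2 and compound 3 cannot be told apart in this read-out. No measurement at hand offers any explanation of these small differences.

All three compounds carry an aromatic ring at this position, which leaves open whether a group of another kind there, such as a longer chain ending in an amine or a carboxylic acid, would move the read-out beyond the scatter. The shared core is also the same throughout, so the effect of replacing its nitro group with an amine remains an open question.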